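The source may report more compounds than this note shows. Statements on the series, on what has been measured and on what is new or still open speak of the compounds shown alone.

Measured values in a functional assay on the whole organism (strain Sprague-Dawley) for inhibition, with Rattus norvegicus as the target, with a stated time of 10 min (a higher number here means that more compound is needed for the effect, a lower number that less compound is needed), are these:

- Compound 1 `CCOC(=O)c1cnc(-c2ccccc2F)[nH]c1=O` gives > 10 mg/kg (a limit)
- Compound 2 `CCOC(=O)c1cnc(-c2ccccc2[N+](=O)[O-])[nH]c1=O` has "not determined" (no result reported) as its entry
- Compound 3 `CCOC(=O)c1cnc(-c2ccccc2OCc2ccccc2)[nH]c1=O` gives > 5 mg/kg (a limit)

From the compounds shown here alone, compound 3 stands with > 5 mg/kg as its entry, which is a limit and not a number, so its exact place in this assay is unknown. The next compound to be tested is compound 4 `CCOC(=O)c1cnc(-c2ccccc2SCC)[nH]c1=O`, which has ethylsulfanyl in place of benzyloxy on an aromatic carbon, ortho to a large group: ethylsulfanyl in place of benzyloxy on an aromatic carbon.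

Within the data shown here, only one measured step bears on this change: a step that the two limits leave unreadable from compound 1 to compound 3, which swaps the group on the same carbon. That step has no readable size to carry over, and compound 2 adds no result. Among the measured compounds shown here, no step of known size or direction can therefore be expected, and a report of only a limit is quite likely. Compound 3 with > 5 mg/kg as its limit remains the anchor for this expectation. The step that the estimate implies is expected to be a step that the limit leaves unreadable from compound 3 to compound 4 in size. For compound 4 the expected dose is 8 mg/kg as a rough estimate, with an estimated range from 2 mg/kg to 25 mg/kg for the measurement.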

Compound 4, dose for 50% inhibition: > 5 mg/kg
Compound 4 was reported as a limit; the forecaster's own chance of this, stated with the estimate: 65%; the middle value is on the limit's open side.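

Compound 4 gives > 5 mg/kg, which is a limit and not a number. Compound 1 and compound 3 also stand only as limits, and no step among these three compounds can be read. The compounds shown leave open the actual dose for each, and whether fluoro, benzyloxy or ethylsulfanyl on that aromatic carbon changes it.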